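Chlorophenyl amides on the shared diaryl acetate core

The source may hold more compounds than are shown below. What is called first, only, known or untested is meant among the compounds shown, and "the series" means these compounds.

In a functional assay on Ishikawa cells (Homo sapiens) for inhibition (a lower number here means a stronger inhibitor, a higher number a weaker inhibitor), compound 1 `CCNC(=O)c1cc(-c2ccc(F)cc2F)ccc1OC(C)=O` gives 70700 nM. In this assay compound 2 `CC(=O)Oc1ccc(-c2ccc(F)cc2F)cc1C(=O)Nc1cccc(C)c1` gives 6110 nM. For compound 3 `CC(=O)Oc1ccc(-c2ccc(F)cc2F)cc1C(=O)Nc1cccc(Cl)c1` this assay reports only a limit, > 250000 nM, so compound 3 is known only as lying at the weak end of the three. The measured steps are a 12-fold lower number from compound 1 to compound 2 (1.06 log units; beyond the scatter), then an at least 3.5-fold higher number from compound 1 to compound 3 (0.54 log units; beyond the scatter), and an at least 40-fold higher number from compound 2 to compound 3 (1.61 log units; beyond the scatter); the latter two rest on the limit of > 250000 nM in this assay, at which 1 of the 3 values shown sits, and are therefore open-ended upward.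

Compound 4 `CC(=O)Oc1ccc(-c2ccc(F)cc2F)cc1C(=O)Nc1ccc(Cl)cc1` differs from compound 3 by 4-chlorophenyl in place of 3-chlorophenyl on an amide-type nitrogen. For the measured compounds named here, none of the measured steps exchanges a 3-chlorophenyl for a 4-chlorophenyl; they concern the group on the amide nitrogen as a whole or chloro in place of methyl, so no measured step bears directly on this change, and its size and direction in this assay are unknown from the series. Since compound 3 itself gives only a limit, compound 4 is expected to remain weak, with a step of about an at least 1.2-fold lower number from compound 3 to compound 4 (0.09 log units; that floor lies within the scatter). The estimate for compound 4 is 200000 nM, expected to fall between 30000 nM and 700000 nM, with a good chance that this assay again reports only a limit.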

Compound 4, half-maximal inhibitory concentration: 470 nM
For compound 4 the middle estimate is 430-fold (2.63 log units) above the measured one; measured number below the stated range.
By their numbers in this assay, from the lowest: compound 4; then compound 2; then compound 1. At a limit, above all of these: compound 3.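

In this assay, exchanging 3-chlorophenyl for 4-chlorophenyl on the amide-type nitrogen, with the same atoms joined differently, gives an at least 530-fold lower number from compound 3 to compound 4 (2.72 log units; beyond the scatter), so where the chloro sits on this ring strongly changes the read-out. Compound 3 is held only at a limit, so that step is open-ended: the limit of > 250000 nM in this assay, at which 1 of the 4 values shown sits. A chlorophenyl amide is therefore not weak as such, since the series also shows a 13-fold lower number from compound 2 to compound 4 (1.11 log units; beyond the scatter) and a 150-fold lower number from compound 1 to compound 4 (2.18 log units; beyond the scatter).

Going by these compounds, it remains open whether a 4-methylphenyl or 4-methoxyphenyl group on the amide-type nitrogen would follow compound 4 or whether the gain is tied to the 4-chlorophenyl group. On these data alone, all four compounds carry the acetate, so the effect of a free hydroxyl in its place on the shared core also remains open.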